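This account rests on a few compounds, and the source may have more. Where it says the series, first, only, none or still open, it means among the compounds named here.

Compound 1 `O=C(c1ccc(Cl)cc1)N1CCC(NS(=O)(=O)c2cc(S(=O)(=O)c3ccccc3)ccc2C(F)(F)F)CC1` is one of three compounds sharing a core and differing only in the group on the amine nitrogen in a ring. In an assay on U2OS cells for inhibition of secreted frizzled-related protein 1 (Homo sapiens), read by a luciferase reporter, with a stated time of 18 h (on this read-out higher numbers stand for an effect only at larger amounts of compound and lower numbers for an effect already at smaller amounts), compound 1 gives 1800 nM, the highest of the three numbers. Compound 2 `O=C(c1ccccn1)N1CCC(NS(=O)(=O)c2cc(S(=O)(=O)c3ccccc3)ccc2C(F)(F)F)CC1` gives 230 nM and compound 3 `O=C(c1ccc(Cl)nc1)N1CCC(NS(=O)(=O)c2cc(S(=O)(=O)c3ccccc3)ccc2C(F)(F)F)CC1` gives 140 nM, so that the step of a 7.8-fold lower number from compound 1 to compound 2 (0.89 log units; beyond the scatter) and the step of a 13-fold lower number from compound 1 to compound 3 (1.11 log units; beyond the scatter) both go well beyond the scatter, while the step of a 1.6-fold lower number from compound 2 to compound 3 (0.22 log units; within the scatter) does not.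

Compound 4 `CC(C)(O)CCN1CCC(NS(=O)(=O)c2cc(S(=O)(=O)c3ccccc3)ccc2C(F)(F)F)CC1` differs from compound 1 in one place: 3-hydroxy-3-methylbutyl in place of (4-chlorophenyl)carbonyl on an amine nitrogen in a ring. Among the measured compounds shown here, no measured step bears directly on this change. Each measured step swaps one aromatic ring on a carbonyl carbon for another and keeps the carbonyl, whereas in compound 4 the carbonyl and its ring leave together and a chain with one hydrogen-bond donor enters. For the measured compounds named here, the measured steps show only that the group on this nitrogen can move the number by a modest to large amount; they give no direction for a change of this kind. The estimate for compound 4 is therefore set near compound 1, with a wide range, as a step of a 1.4-fold higher number from compound 1 to compound 4 (0.14 log units; within the scatter) that is expected to stay within the scatter. Compound 4 is expected to give about 2500 nM in this assay, between 500 nM and 12000 nM.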

Compound 4, half-maximal effective concentration: 630 nM
Beside the measured number, compound 4's estimate is 4.0-fold (0.60 log units) above it, within the range that was stated.
By their numbers in this assay, from the lowest: compounds 3 and 2 (each within the scatter of the next); then compound 4; then compound 1.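

On the amine nitrogen in the ring, the carbonyl and its aromatic ring can leave together without the number rising: in this assay, 3-hydroxy-3-methylbutyl in place of (4-chlorophenyl)carbonyl gives a 2.9-fold lower number from compound 1 to compound 4 (0.46 log units; beyond the scatter). The same chain does not match the two pyridine-bearing carbonyl groups, with a 2.7-fold higher number from compound 2 to compound 4 (0.44 log units; beyond the scatter) and a 4.5-fold higher number from compound 3 to compound 4 (0.65 log units; beyond the scatter), so a group with no ring and no carbonyl falls among the aromatic amides rather than outside them. No measurement at hand explains these steps.

The compounds shown leave open how much of this result rests on the hydroxyl, which a plain 3-methylbutyl chain would test. They also leave open how a chain ending in an amine or a carboxylic acid, or a longer chain, would compare.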